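Replacing the bromothiophene ketone with a pyrrole ketone

The source may hold more compounds than are shown below. What is called first, only, known or untested is meant among the compounds shown, and "the series" means these compounds.

Two compounds of the series have been run in a functional assay on NCI-H460 cells (Homo sapiens) for antiproliferative activity, read by XTT assay, with a stated time of 72 h (a higher number here means a weaker inhibitor, a lower number a stronger inhibitor), so far. Compound 1 `COc1ccc(-c2cc3ccccc3nc2/C=C/C(=O)c2ccc([N+](=O)[O-])cc2)cc1` gives 6470 nM. Compound 2 `COc1ccc(-c2cc3ccccc3nc2/C=C/C(=O)c2ccc(Br)s2)cc1` gives 5170 nM. For the measured compounds named here, the single step between them, a 1.3-fold lower number from compound 1 to compound 2 (0.10 log units; within the scatter), does not separate the two beyond the scatter, so compound 2 cannot be called the stronger of the pair; it simply holds the lower of the two numbers recorded.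

Compound 3 `COc1ccc(-c2cc3ccccc3nc2/C=C/C(=O)c2ccc[nH]2)cc1` differs from compound 2 only at the carbonyl carbon: 1H-pyrrol-2-yl in place of 5-bromothiophen-2-yl on a carbonyl carbon. Going by the values given here, the one measured step that touches this position, the exchange from compound 1 to compound 2, changed the number by a 1.3-fold lower number from compound 1 to compound 2 (0.10 log units; within the scatter), and no measured step covers a ring with a hydrogen-bond donor in this place. With only that small, inconclusive step to go on, the expected movement in this assay from compound 2 to compound 3 is a 1.2-fold higher number from compound 2 to compound 3 (0.06 log units; within the scatter), a change not expected to exceed the scatter in either direction. On this basis compound 3 is estimated at 6000 nM, with a range from 2500 nM to 15000 nM.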

Compound 3, half-maximal inhibitory concentration: > 10000 nM
Compound 3 was reported as a limit; the forecaster's own chance of this, stated with the estimate: 5%; middle value at least 1.6-fold (0.22 log units) away from the limit.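

In this assay, for the compounds shown here, compound 3 is reported only as a limit, > 10000 nM, and 1H-pyrrol-2-yl is the first group on this carbonyl carbon to give a limit rather than a number. Against the two earlier groups, the result can be read only as floors, an at least 1.9-fold higher number from compound 2 to compound 3 (0.28 log units; that floor lies within the scatter) and an at least 1.5-fold higher number from compound 1 to compound 3 (0.18 log units; that floor lies within the scatter), so neither step establishes a separation beyond the scatter, though the real gaps may be larger than these floors. What is new at this position is therefore a boundary on the comparison rather than a measured size of change, and the series has only one such case so far: the limit of > 10000 nM in this assay, at which 1 of the 3 values shown sits.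

The exchange from 5-bromothiophen-2-yl to 1H-pyrrol-2-yl changes the hetero atom, removes the bromine and brings in a hydrogen-bond donor all at once, and the compounds shown do not tell these changes apart. As far as these compounds go, a methyl group on the pyrrole nitrogen, or a thiophene ring without bromine, on the same carbonyl carbon would bear on that question, while the size of the step to compound 3 stays open as long as its value remains a limit.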